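The source may hold more compounds than are shown below. What is called first, only, known or untested is meant among the compounds shown, and "the series" means these compounds.

Measured in a functional assay on M21 cells (Homo sapiens) for antiproliferative activity, read by sulforhodamine B assay, with a stated time of 48 h; a higher number here means a weaker inhibitor, a lower number a stronger inhibitor:

- Compound 1 `Cc1ccc(OS(=O)(=O)c2ccc(N3CCN(C)C3=O)cc2)c(C)c1` gives 1800 nM
- Compound 2 `CN1CCN(c2ccc(S(=O)(=O)Oc3cccc(I)c3)cc2)C1=O` gives 400 nM
- Compound 3 `CN1CCN(c2ccc(S(=O)(=O)Oc3ccc(F)cc3)cc2)C1=O` gives > 100000 nM, which is a limit

Compound 3 stands at the weak end of this set, and what it has is a limit of the assay, not a number. Compound 4 `CN1CCN(c2ccc(S(=O)(=O)Oc3ccc(Cl)cc3)cc2)C1=O` differs from it in one place, with chloro in place of fluoro on an aromatic carbon, para to a large group (chloro in place of fluoro on an aromatic carbon). Among the compounds with values here, no measured step exchanges these two groups. The nearest evidence is the pair of steps leading into compound 3. Taking 4-fluorophenyl in place of 3-iodophenyl gives an at least 250-fold higher number from compound 2 to compound 3 (2.39 log units; beyond the scatter), and taking it in place of 2,4-dimethylphenyl gives an at least 55-fold higher number from compound 1 to compound 3 (1.74 log units; beyond the scatter). Both are large, whereas the step between the two numerically measured compounds, a 4.5-fold lower number from compound 1 to compound 2 (0.65 log units; beyond the scatter), is modest. The 4-fluorophenyl compound therefore sits far from the other two, and a change at that same group could plausibly move the value a long way. A lower number is expected in this assay, although the true size of the step cannot be fixed from a limit. The estimate means an at least 12-fold lower number from compound 3 to compound 4 (1.09 log units; beyond the scatter), an expected large step. Compound 4 is estimated at 8000 nM, with an expected range from 1500 nM to 60000 nM.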

Compound 4, half-maximal inhibitory concentration: 43000 nM
Compound 4: middle estimate off by 5.4-fold (0.73 log units), on the low side; low and high end bracket the measured number.
By their numbers in this assay, from the lowest: compound 2; then compound 1; then compound 4. At a limit, above all of these: compound 3.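

In this assay, chloro in place of fluoro on this aromatic carbon, para to a large group, brings the value down into the measurable range (an at least 2.3-fold lower number from compound 3 to compound 4 (0.36 log units; beyond the scatter)), so this position responds to a change of a single halogen. Compound 3 holds only a limit, not a number, so that step gives the least the change can be and not its true size: the limit of > 100000 nM in this assay, at which 1 of the 4 values shown sits. Even so, the 4-chlorophenyl compound stays far from the other two (a 110-fold higher number from compound 2 to compound 4 (2.03 log units; beyond the scatter); a 24-fold higher number from compound 1 to compound 4 (1.38 log units; beyond the scatter)), which shows that chloro at this position does not by itself reach the level of the 3-iodophenyl or 2,4-dimethylphenyl groups.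

The compounds shown leave open whether the place of a group on the ring or the identity of the group sets the value, as the 3-iodophenyl and 4-chlorophenyl compounds differ in both. Also open, going by these compounds, is how far the value would move with bromo, iodo or methoxy at this same position, and whether a 3-chlorophenyl group would stand nearer to compound 2.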